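The source may report more compounds than this note shows. Statements on the series, on what has been measured and on what is new or still open speak of the compounds shown alone.

Measured compounds:
compound 1, `COc1ccc2nc(Nc3ccnc(Nc4ccc(S(N)(=O)=O)cc4)n3)sc2c1`: 1730 nM
compound 2, `NS(=O)(=O)c1ccc(Nc2nccc(Nc3nc4ccccc4s3)n2)cc1`: 2060 nM
compound 3, `Cc1ccc2nc(Nc3nc(Nc4ccc(S(N)(=O)=O)cc4)ncc3C)sc2c1`: 3280 nM

All three were tested in a functional assay on HeLa cells (Homo sapiens) for antiproliferative activity, read by MTT assay, with a stated time of 48 h; a lower number here means a stronger inhibitor, a higher number a weaker inhibitor. Compound 3 gives the highest of the three numbers, yet its distance to compound 2 and to compound 1 is within the scatter, so no order among them can be stated. Compound 4, `Cc1ccc2nc(Nc3ccnc(Nc4ccc(S(N)(=O)=O)cc4)n3)sc2c1`, is not yet measured. It differs from compound 3 by hydrogen in place of methyl on an aromatic carbon. Among the compounds with values here, the only measured step, a 1.2-fold higher number from compound 1 to compound 2 (0.08 log units; within the scatter), also replaces a group with hydrogen, but on a different ring, and it stayed within the scatter. Within the data shown here, no measured step touches the methyl of compound 3. Compound 4 is therefore expected to show no step beyond the scatter, a 1.6-fold lower number from compound 3 to compound 4 (0.21 log units; within the scatter), and its estimated value is 2000 nM, within 1000 nM to 4000 nM.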

Compound 4, half-maximal inhibitory concentration: 660 nM
The estimate for compound 4 lay 3.0-fold (0.48 log units) above the measured number; measured number outside the range, below it.
By their numbers in this assay, from the lowest: compound 4; then compounds 1, 2 and 3 (each within the scatter of the next).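

In this assay, the methyl on the six-membered aromatic ring with 2 nitrogen proves to matter: losing it gives a 5.0-fold lower number from compound 3 to compound 4 (0.70 log units; beyond the scatter), a step beyond the scatter. On the other ring, where hydrogen and methoxy had stayed within the scatter of each other, methyl now stands apart, with a 3.1-fold lower number from compound 2 to compound 4 (0.49 log units; beyond the scatter) and a 2.6-fold lower number from compound 1 to compound 4 (0.42 log units; beyond the scatter). Nothing measured here explains these steps. Going by these compounds, whether a chlorine or an ethyl in place of that methyl on the other ring would match it remains open, as does how an amine would fare on the six-membered aromatic ring with 2 nitrogen.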